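HDAC-type benzamide series: thiourea linker, aryl tail exchange

This account rests on a few compounds, and the source may have more. Where it says the series, first, only, none or still open, it means among the compounds named here.

Measured compounds in a functional assay on HCT-116 cells (Homo sapiens) for cytotoxicity, read by MTT assay, with a stated time of 72 h; a higher number here means a weaker inhibitor, a lower number a stronger inhibitor:
- compound 1 `Nc1ccccc1NC(=O)c1ccc(CNC(=O)c2cc3cccnc3[nH]2)cc1`: 10000 nM
- compound 2 `Nc1ccccc1NC(=O)c1ccc(NC(=S)NCc2cncc(F)c2)cc1`: 15000 nM
- compound 3 `Nc1ccccc1NC(=O)c1ccc(NC(=O)NCc2ccc(F)nc2)cc1`: 14000 nM

All three share the same benzamide core and differ in the linker and the aryl tail. In this assay compound 2 gives 15000 nM, a number that sits alongside those of compound 3 and compound 1; each of those values lies within the usual scatter of compound 2, so no order among the three can be read from them. Among the compounds with values here, none of the measured pairs differs in a single place, so no isolated step is available.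

Compound 4 `Nc1ccccc1NC(=O)c1ccc(NC(=S)NCc2cccc(Cl)c2)cc1` is the next member and has not yet been measured. It differs from compound 2 as follows: 3-chlorophenyl in place of 5-fluoropyridin-3-yl on a saturated chain carbon bound to an amide-type nitrogen. The exchange replaces one six-membered aromatic ring with 1 hetero atom by one six-membered aromatic ring of carbon only, with the thiourea and the rest of the molecule unchanged.

Within the data shown here, with no measured step touching this part of the series, no direction can be set for this assay; a step within the scatter is the expectation. The value of compound 4 in this assay is expected near 12000 nM, within 5000 nM to 30000 nM, which corresponds to an expected step of a 1.3-fold lower number from compound 2 to compound 4 (0.10 log units; within the scatter).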

Compound 4, half-maximal inhibitory concentration: 5900 nM
Beside the measured number, compound 4's estimate is 2.0-fold (0.31 log units) above it, and the stated range covers the measured number.
By their numbers in this assay, from the lowest: compounds 4, 1, 3 and 2 (each within the scatter of the next, the first and the last beyond it).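

In this assay the series now has a single-place step, and it lies beyond the scatter: a 2.5-fold lower number from compound 2 to compound 4 (0.41 log units; beyond the scatter). The aryl tail on the saturated chain carbon bound to an amide-type nitrogen is therefore a place where the number can move, and with the thiourea and the rest of the molecule unchanged, 3-chlorophenyl gives the lower number, although the step is modest and rests on one pair. Nothing available here explains the step.

The exchange removes the ring nitrogen and the fluorine and brings in chlorine in one move, so the compounds shown leave open which of these changes carries the step. Also open, from the compounds shown here alone, is how a plain phenyl ring, or a trifluoromethyl group in place of the chlorine, would read in this position.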